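Isopropyl in place of diethylcarbamoyl on the saturated ring

The compounds below may be only part of what the source reports. "The series", "measured", "known", "first", "only" and "open" are said of these compounds alone.

Compound 1 `CCCCC(CC)N(Cc1ccc(C(=O)NCCC(=O)O)cc1)C(=O)Nc1ccc(OC(F)(F)F)cc1` gives 141 nM in an in vitro assay on BHK cells for inhibition of Glucagon receptor (Homo sapiens); on this read-out higher numbers stand for weaker inhibition and lower numbers for stronger inhibition. Compound 2 `COC1CCC(N(Cc2ccc(C(=O)NCCC(=O)O)cc2)C(=O)Nc2ccc(OC(F)(F)F)cc2)CC1` reaches only the limit > 10000 nM in this assay. Compound 3 `CCN(CC)C(=O)C1CCC(N(Cc2ccc(C(=O)NCCC(=O)O)cc2)C(=O)Nc2ccc(OC(F)(F)F)cc2)CC1` gives 782 nM in this assay.

Among the measured compounds shown here, of the two numbers in hand, compound 3 holds the higher one, with compound 1 the only other numbered neighbour. Compound 4 `CC(C)C1CCC(N(Cc2ccc(C(=O)NCCC(=O)O)cc2)C(=O)Nc2ccc(OC(F)(F)F)cc2)CC1` has not yet been measured; it differs from compound 3 by isopropyl in place of diethylcarbamoyl on a saturated ring carbon. Two earlier steps touched the same place on the ring. The step of an at least 70-fold higher number from compound 1 to compound 2 (1.85 log units; beyond the scatter) was large, and the step of an at least 12-fold lower number from compound 2 to compound 3 (1.10 log units; beyond the scatter) was also large, in the opposite direction. Both show that what sits on this ring carbon can move the number a long way. An isopropyl is a small, plain group of three carbons, closer in kind to the branched alkyl of compound 1 than to the methoxy of compound 2, so the step of a 2.0-fold lower number from compound 3 to compound 4 (0.29 log units; within the scatter) is expected to be modest and downward, though with wide uncertainty. Compound 4 is therefore expected to give about 400 nM, somewhere between 80 nM and 2500 nM.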

Compound 4, half-maximal inhibitory concentration: 59 nM
Beside the measured number, compound 4's estimate is 6.8-fold (0.83 log units) above it; measured number below the stated range.
By their numbers in this assay, from the lowest: compound 4; then compound 1; then compound 3. At a limit, above all of these: compound 2.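

On the saturated ring carbon three ring bonds from the ring atom that bears a large group, isopropyl gives the best result of the three groups shown in this assay: a 13-fold lower number from compound 3 to compound 4 (1.12 log units; beyond the scatter) and an at least 160-fold lower number from compound 2 to compound 4 (2.22 log units; beyond the scatter). The ring is also compatible with a lower number than the open chain, which compound 2 and compound 3 did not show: a 2.4-fold lower number from compound 1 to compound 4 (0.38 log units; beyond the scatter). Compound 2 gives a limit, not a number, so its step is only a bound: the limit of > 10000 nM in this assay, at which 1 of the 4 values shown sits.

With only methoxy, diethylcarbamoyl and isopropyl on this ring carbon, these compounds cannot tell whether the heavy-atom count or the presence of oxygen and nitrogen matters more. Going by these compounds, how a tert-butyl group, a longer chain, an amine or a carboxylic acid would read at the same carbon remains open.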